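A few compounds are considered here, and "the series" means these few. Any claim that something is new, unique, unknown or untested is made for them only; others in the source may bear on it.

Compound 1 `O=C(Nc1ccc(-n2ncc3ccccc32)cc1)Nc1ccc(Cl)c(C(F)(F)F)c1` gives 8700 nM in a functional assay on LoVo cells (Homo sapiens) for cytotoxicity, read by MTT assay, with a stated time of 72 h; a higher number here means a weaker inhibitor, a lower number a stronger inhibitor. Compound 2 `O=C(Nc1ccc(-n2ncc3cnccc32)cc1)Nc1ccc(Cl)c(C(F)(F)F)c1` gives 8000 nM in this assay, and the step of a 1.1-fold lower number from compound 1 to compound 2 (0.04 log units; within the scatter) leaves the two numbers within the scatter of each other, so compound 2 cannot be set apart from compound 1 on these data. Compound 3 `O=C(Nc1ccc(-n2ncc3cccnc32)cc1)Nc1ccc(Cl)c(C(F)(F)F)c1` has the same atoms as compound 2, joined differently: a group of 9 heavy atoms (6 carbon, 3 nitrogen; one five-membered aromatic ring with 2 hetero atoms, one six-membered aromatic ring with 1 hetero atom) in place of a group of 9 heavy atoms (6 carbon, 3 nitrogen; one five-membered aromatic ring with 2 hetero atoms, one six-membered aromatic ring with 1 hetero atom), on an aromatic carbon. Among the compounds with values here, the only measured step that bears on this, a 1.1-fold lower number from compound 1 to compound 2 (0.04 log units; within the scatter), also rearranged the same part of the molecule and did not move the number beyond the scatter. The step of no change at the digits printed from compound 2 to compound 3 (within the scatter) is therefore expected to be small, with no clear direction. Compound 3 is estimated to give 8000 nM in this assay, within a range from 4000 nM to 16000 nM.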

Compound 3, half-maximal inhibitory concentration: 32000 nM
The estimate for compound 3 lay 4.0-fold (0.60 log units) below the measured number; the measured number lies above the stated range.
By their numbers in this assay, from the lowest: compounds 2 and 1 (each within the scatter of the next); then compound 3.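

At this place, on an aromatic carbon para to a large group, the way the atoms of the group are joined matters in this assay: a 4.0-fold higher number from compound 2 to compound 3 (0.60 log units; beyond the scatter), although the two groups match in their counts of heavy atoms, hydrogen-bond donors and hydrogen-bond acceptors. Within the data shown here, exchanging the group of the first compound for one with an added nitrogen is thus not neutral in every arrangement, since a 1.1-fold lower number from compound 1 to compound 2 (0.04 log units; within the scatter), while a 3.7-fold higher number from compound 1 to compound 3 (0.57 log units; beyond the scatter). Nothing available explains why the arrangement in compound 3 gives the higher number.

The compounds shown leave open whether other arrangements of the nitrogen atoms in this group would stay close to compound 2 or rise as compound 3 does. They also leave open how an amine or a carboxylic acid carried on this group would change the number.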